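Changing the Group on the Ring Nitrogen: Expected Tolerance

This account rests on a few compounds, and the source may have more. Where it says the series, first, only, none or still open, it means among the compounds named here.

Measured in an ADME assay on HepG2 cells (Homo sapiens) for cytotoxicity, read by MTT assay, with a stated time of 24 h; a lower number here means that less compound is tolerated, a higher number that more compound is tolerated:
Compound 1 `CC(C)=CCC1=C(OCc2cn(-c3ccnc4cc(Cl)ccc34)nn2)C(=O)c2ccccc2C1=O` gives 1940000 nM
Compound 2 `CC(C)=CCC1=C(OCc2cn(Cc3ccccn3)nn2)C(=O)c2ccccc2C1=O` gives 658000 nM
Compound 3 `CC(C)=CCC1=C(OCc2cn(-c3ccc(S(N)(=O)=O)cc3)nn2)C(=O)c2ccccc2C1=O` gives 483000 nM

Compound 2 stands second highest of the three numbers. Its nearest neighbour is compound 3, reached by a 1.4-fold lower number from compound 2 to compound 3 (0.13 log units; within the scatter), and its furthest is compound 1, from which it lies a 2.9-fold lower number from compound 1 to compound 2 (0.47 log units; beyond the scatter).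

Compound 4 `CC(C)=CCC1=C(OCc2cn(-c3ccc([N+](=O)[O-])cc3)nn2)C(=O)c2ccccc2C1=O` has not been measured. It differs from compound 2 in one place: 4-nitrophenyl in place of (pyridin-2-yl)methyl on an aromatic nitrogen.

For the measured compounds named here, two measured steps bear on this change. The step of a 1.4-fold lower number from compound 2 to compound 3 (0.13 log units; within the scatter) also replaces (pyridin-2-yl)methyl with a six-membered aromatic ring of carbon only on the same ring nitrogen, and it stays within the scatter. The step of a 4.0-fold lower number from compound 1 to compound 3 (0.60 log units; beyond the scatter) shows that two different ring groups on that nitrogen can differ modestly. Going by the values given here, no measured compound carries 4-nitrophenyl, so that part of the change has no direct support. Compound 4 is therefore expected to show a step of a 1.1-fold lower number from compound 2 to compound 4 (0.04 log units; within the scatter) in this assay, none beyond the scatter. The estimate for compound 4 is 600000 nM, with a range from 250000 nM to 1500000 nM.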

Compound 4, half-maximal cytotoxic concentration: 540000 nM
Estimate against measurement, compound 4: 1.1-fold (0.05 log units) above; low and high end bracket the measured number.
By their numbers in this assay, from the lowest: compounds 3, 4 and 2 (each within the scatter of the next); then compound 1.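

In this assay, replacing (pyridin-2-yl)methyl with 4-nitrophenyl on the ring nitrogen gives a 1.2-fold lower number from compound 2 to compound 4 (0.09 log units; within the scatter), so a third, quite different group leaves the number essentially unchanged. Exchanging sulfamoyl for nitro on the aromatic carbon of the phenyl ring gives a 1.1-fold higher number from compound 3 to compound 4 (0.05 log units; within the scatter), the first change shown on that ring itself, and it also stays within the scatter. Against this, a 3.6-fold lower number from compound 1 to compound 4 (0.56 log units; beyond the scatter) shows that compound 1, with its 7-chloroquinolin-4-yl group, remains the only compound apart from the others.

Nothing available explains why compound 1 stands apart. Still open, on these data alone, is whether a phenyl ring bearing an amine or a carboxylic acid would stay with compound 2, compound 3 and compound 4, and whether a quinolin-4-yl group without the chlorine would stay with compound 1.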